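Amide substituent changes on the pyrrolidine nitrogen of the series

This account rests on a few compounds, and the source may have more. Where it says the series, first, only, none or still open, it means among the compounds named here.

Measured so far:
Compound 1 `C[C@@H](O[C@@H]1CN(C(=O)C(C)(C)C)C[C@H]1c1ccccc1)c1cc(C(F)(F)F)cc(C(F)(F)F)c1` gives 0.18 nM.
Compound 2 `Cc1cnc(C(=O)N2C[C@@H](O[C@H](C)c3cc(C(F)(F)F)cc(C(F)(F)F)c3)[C@H](c3ccc(F)cc3)C2)cn1` gives 0.12 nM.
Compound 3 `C[C@@H](O[C@@H]1CN(C(=O)N2CCOCC2)C[C@H]1c1ccccc1)c1cc(C(F)(F)F)cc(C(F)(F)F)c1` gives 0.16 nM.

In an assay on CHO cells for displacement of a labelled ligand from Substance-P receptor (Homo sapiens) (a lower number here means a stronger inhibitor, a higher number a weaker inhibitor), compound 2 has the lowest number of the three, but its gaps to compound 3 and to compound 1 are both within the scatter, so no order among the three can be read from these values.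

Compound 4 `C[C@@H](O[C@@H]1CN(C(=O)NC(C)(C)C)C[C@H]1c1ccc(F)cc1)c1cc(C(F)(F)F)cc(C(F)(F)F)c1` is not yet measured. It differs from compound 2 by (tert-butyl)amino in place of 5-methylpyrazin-2-yl on a carbonyl carbon, the same difference read one bond further out being (5-methylpyrazin-2-yl)carbonyl to (tert-butyl)carbamoyl.

Within the data shown here, one measured step bears on this position: a 1.1-fold lower number from compound 1 to compound 3 (0.05 log units; within the scatter), which replaces one group on the carbonyl carbon with another of quite different build and leaves the number where it was. The present change also swaps one carbonyl substituent for another, so no step beyond the scatter is expected in this assay. The expected step is a 1.3-fold higher number from compound 2 to compound 4 (0.10 log units; within the scatter), in no clear direction. For compound 4 the estimate is 0.15 nM, with a range of 0.06 nM to 0.4 nM.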

Compound 4, half-maximal inhibitory concentration: 0.14 nM
Compound 4: the middle estimate sits 1.1-fold (0.03 log units) above what was measured, and the stated range covers the measured number.
By their numbers in this assay, from the lowest: compounds 2, 4, 3 and 1 (each within the scatter of the next).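

In this assay, the change of 5-methylpyrazin-2-yl to (tert-butyl)amino on the carbonyl carbon gives a 1.2-fold higher number from compound 2 to compound 4 (0.07 log units; within the scatter). This extends the earlier picture: an aromatic ring with hetero atoms gives way to a group with no ring and a hydrogen-bond donor, yet the step stays within the scatter, so this position has not yet shown a substituent that separates from the others. No measured data offer an explanation for this flat result.

The compounds shown do not define what would shift the number at this position, as all of their differences here lie within the scatter. As far as these compounds go, it remains open how a carboxylic acid or a primary amine carried on a longer chain from the carbonyl carbon would read in this assay.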